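Small swaps on a shared core in a clearance read-out

A few compounds are considered here, and "the series" means these few. Any claim that something is new, unique, unknown or untested is made for them only; others in the source may bear on it.

Measured in an ADME assay (liver) for metabolic stability, with Liver microsome (Homo sapiens) as the target, using microsomes and NADPH, with a stated time of 30 min, tested at 1 uM; on this read-out higher numbers stand for fast clearance and lower numbers for slow clearance:
- compound 1 `Nc1ccc(S(=O)(=O)N2CCN(c3ncc(C(O)(C(F)(F)F)C(F)(F)F)cc3C3CC3)CC2)cn1`: 38 mL.min-1.g-1
- compound 2 `Cc1csc(-c2cc(C(O)(C(F)(F)F)C(F)(F)F)cnc2N2CCN(S(=O)(=O)c3ccc(N)nc3)CC2)c1`: 29 mL.min-1.g-1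
- compound 3 `COc1ccc(-c2cc(C(O)(C(F)(F)F)C(F)(F)F)cnc2N2CCN(S(=O)(=O)c3ccc(N)nc3)CC2)cn1`: 25 mL.min-1.g-1

Compound 3, at 25 mL.min-1.g-1, lies within the usual scatter of both other compounds, so the three cannot be ranked. The next change gives compound 4 `Nc1ccc(S(=O)(=O)N2CCN(c3ncc(C(O)(C(F)(F)F)C(F)(F)F)cc3-c3ccc4scnc4c3)CC2)cn1`: 1,3-benzothiazol-5-yl in place of 6-methoxypyridin-3-yl on an aromatic carbon. The closest evidence comes from three swaps of this same group: a 1.3-fold lower number from compound 1 to compound 2 (0.12 log units; within the scatter), a 1.5-fold lower number from compound 1 to compound 3 (0.18 log units; within the scatter) and a 1.2-fold lower number from compound 2 to compound 3 (0.06 log units; within the scatter). All stayed within the scatter, although none brought in 1,3-benzothiazol-5-yl, so the evidence is only partial. No step beyond the scatter is therefore expected in this assay. The estimated step is a 1.2-fold higher number from compound 3 to compound 4 (0.08 log units; within the scatter). For compound 4 the estimated value is 30 mL.min-1.g-1, with a range of 16 mL.min-1.g-1 to 55 mL.min-1.g-1.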

Compound 4, intrinsic clearance in microsomes: 39 mL.min-1.g-1
For compound 4 the middle estimate is 1.3-fold (0.11 log units) below the measured one; low and high end bracket the measured number.
By their numbers in this assay, from the lowest: compounds 3, 2, 1 and 4 (each within the scatter of the next).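

In this assay, the two-ring group 1,3-benzothiazol-5-yl stays within the scatter of each earlier group at this position: 6-methoxypyridin-3-yl (a 1.6-fold higher number from compound 3 to compound 4 (0.19 log units; within the scatter)), 4-methylthiophen-2-yl (a 1.3-fold higher number from compound 2 to compound 4 (0.13 log units; within the scatter)) and cyclopropyl (a 1.0-fold higher number from compound 1 to compound 4 (0.01 log units; within the scatter)). Across these four compounds, then, a group with two aromatic rings gives no step beyond the scatter, just as the smaller groups did. Nothing measured here offers an explanation for these numbers.

Going by these compounds, whether an amine or a carboxylic acid at this position would step beyond the scatter remains open. So does the effect of a swap elsewhere on the shared core.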